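Two hydroxyphenyl pyridines at the assay ceiling, a third expected there

A few compounds are considered here, and "the series" means these few. Any claim that something is new, unique, unknown or untested is made for them only; others in the source may bear on it.

Measured compounds:
compound 1, `Oc1ccc(-c2cc(-c3ccsc3)cc(-c3ccccc3O)n2)cc1`, > 50000 nM
compound 2, `Oc1ccccc1-c1cc(-c2ccccn2)cc(-c2ccccc2O)n1`, > 50000 nM

In a functional assay on HeLa cells (Homo sapiens) for cytotoxicity, read by CCK-8 assay (on this read-out lower numbers stand for stronger inhibition and higher numbers for weaker inhibition), compound 2 gives only a limit, > 50000 nM, and no number. Compound 1 likewise gives only a limit in this assay, > 50000 nM. Within the data shown here, both values therefore sit at the same ceiling, as the limit of > 50000 nM in this assay, at which 2 of the 2 values shown sit, shows, so nothing can be said about how the two compare with each other, and no step between measured compounds is available.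

Compound 3, `Oc1ccc(-c2cc(-c3ccccn3)cc(-c3ccccc3O)n2)cc1`, has the same atoms as compound 2 joined differently: 4-hydroxyphenyl in place of 2-hydroxyphenyl on an aromatic carbon. Compound 1 already carries a 4-hydroxyphenyl group on the shared core and still gives only a limit in this assay, and compound 2 gives only a limit as well.

Compound 3 is therefore expected to remain at or beyond the ceiling of this assay, with an estimated 70000 nM (range 30000 nM to 200000 nM). The step that this estimate implies, a step that the limit leaves unreadable from compound 2 to compound 3, is expected to be none beyond the scatter.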

Compound 3, half-maximal inhibitory concentration: > 50000 nM
Compound 3 ended at the assay's limit (the forecaster's own chance of this, stated with the estimate: 80%); the middle value lies beyond the limit too.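

No step can be read from compound 2 or from compound 1 to compound 3 in this assay, because all three compounds give only a limit and no number: the limit of > 50000 nM in this assay, at which 3 of the 3 values shown sit.

The compounds shown leave open whether 4-hydroxyphenyl in place of 2-hydroxyphenyl, or pyridin-2-yl in place of thiophen-3-yl, makes any difference in this read-out.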